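From morpholin-4-yl to 4-hydroxypiperidin-1-yl on compound 3

The compounds below may be only part of what the source reports. "The series", "measured", "known", "first", "only" and "open" are said of these compounds alone.

Of the compounds shown here, three have been measured so far in a functional assay on A20 cells (Mus musculus) for inhibition, with stated times of 1 h, 16 h and 24 h; on this read-out lower numbers stand for stronger inhibition and higher numbers for weaker inhibition. Compound 1 `N#CCNC(=O)[C@@H]1CC(F)(F)C[C@H]1C(=O)N1CCOCC1` gives 925 nM, compound 2 `N#CCNC(=O)[C@@H]1C[C@@H](S(=O)(=O)c2ccccc2C(F)(F)F)C[C@H]1C(=O)N1CCOCC1` gives 2 nM and compound 3 `N#CC1(NC(=O)[C@@H]2C[C@@H](S(=O)(=O)c3ccccc3)C[C@H]2C(=O)N2CCOCC2)CC1` gives 12 nM. Compound 3 therefore holds the middle place, with a higher number than compound 2 and a lower number than compound 1, and both gaps lie beyond the usual scatter.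

Compound 4 `N#CC1(NC(=O)[C@@H]2C[C@@H](S(=O)(=O)c3ccccc3)C[C@H]2C(=O)N2CCC(O)CC2)CC1` carries 4-hydroxypiperidin-1-yl in place of morpholin-4-yl on a carbonyl carbon. All three measured compounds carry morpholin-4-yl at this place, so the data contain no direct reading of a change there. No step beyond the scatter is therefore expected in this assay, and neither direction is favoured. The expectation starts from compound 3 at 12 nM. The estimated step is a 1.2-fold lower number from compound 3 to compound 4 (0.08 log units; within the scatter), which would lie within the scatter. For compound 4 the estimated value is 10 nM, with an expected range of 4 nM to 30 nM.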

Compound 4, half-maximal inhibitory concentration: 371 nM
Beside the measured number, compound 4's estimate is 37-fold (1.57 log units) below it; the measured number lies above the stated range.
By their numbers in this assay, from the lowest: compound 2; then compound 3; then compound 4; then compound 1.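

Among the compounds shown here, at the carbonyl carbon, this assay gives the first direct reading of a change: 4-hydroxypiperidin-1-yl in place of morpholin-4-yl brings a 31-fold higher number from compound 3 to compound 4 (1.49 log units; beyond the scatter), so this place does not tolerate every six-membered non-aromatic ring. The entering group differs from morpholin-4-yl in ring hetero atoms, in size and in carrying a hydrogen-bond donor, and this single step does not separate these differences. Nothing at hand links the step to any measured property of either group.

Plain piperidin-1-yl or 4-methoxypiperidin-1-yl at this place would show whether the hydroxyl or the loss of the ring oxygen goes with the higher number. On these data alone, it also remains open whether the same exchange carries the same step on the core of compound 2.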